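The compounds below may be only part of what the source reports. "The series", "measured", "known", "first", "only" and "open" are said of these compounds alone.

Measured compounds in the series:

- compound 1 `COc1ccc(-c2nc3cc(F)ccc3[nH]2)c(F)c1`; in an assay for inhibition of Alpha amylase (Homo sapiens), with a stated time of 10 min (a higher number here means a weaker inhibitor, a lower number a stronger inhibitor), compound 1 gives 1590 nM
- compound 2 `COc1ccc(-c2nc3cc(Cl)ccc3[nH]2)c(F)c1`; in this assay compound 2 gives 2740 nM
- compound 3 `COc1cc(Br)c(-c2nc3cc(Cl)ccc3[nH]2)cc1OC`; in this assay compound 3 gives 1730 nM

Compound 2 holds the highest of the three numbers in this assay, but this says little: compound 3 and compound 1 both lie within the scatter of it, so the three measured compounds cannot be ranked against one another.

The next compound is compound 4 `COc1ccc(-c2nc3cc([N+](=O)[O-])ccc3[nH]2)c(F)c1`, which differs from compound 2 in one place: nitro in place of chloro on an aromatic carbon. Within the data shown here, the only measured step at this same position is a 1.7-fold higher number from compound 1 to compound 2 (0.24 log units; within the scatter), a change that stayed within the scatter. Among the measured compounds shown here, no measured compound carries a nitro group, so there is no step that directly covers the change from chloro to nitro; the shared core of compound 1, compound 2 and compound 4 is otherwise unchanged.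

From the compounds shown here alone, on that basis the expected step is a 1.1-fold lower number from compound 2 to compound 4 (0.04 log units; within the scatter), that is, no movement beyond the scatter in either direction, with the range kept wide because the nitro group is untested here. Compound 4 is estimated at 2500 nM in this assay, within 900 nM to 7000 nM.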

Compound 4, half-maximal inhibitory concentration: 2750 nM
Compound 4: the middle estimate sits 1.1-fold (0.04 log units) below what was measured, within the range that was stated.
By their numbers in this assay, from the lowest: compounds 1, 3, 2 and 4 (each within the scatter of the next).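

In this assay, nitro in place of chloro gives a 1.0-fold higher number from compound 2 to compound 4 (0.00 log units; within the scatter) and nitro in place of fluoro gives a 1.7-fold higher number from compound 1 to compound 4 (0.24 log units; within the scatter) on the same aromatic carbon of the shared core. This position now carries three different groups, and every step among fluoro, chloro and nitro lies within the scatter, whereas before only the change from fluoro to chloro could be read. The change also goes beyond a swap of one halogen for another, with a single chlorine leaving and three heavy atoms with two hydrogen-bond acceptors entering, and still no step beyond the scatter appears; no measurement available here offers an explanation for this flat result.

From the compounds shown here alone, whether a different kind of group at this position, such as an amine or a carboxylic acid, would give a step beyond the scatter remains open. Also open, going by these compounds, is whether nitro in place of chloro would read the same on the core of compound 3, which differs from compound 2 in more than one place.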